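Fluoro for methoxy on the aryl piperazine of compound 3

The source may report more compounds than this note shows. Statements on the series, on what has been measured and on what is new or still open speak of the compounds shown alone.

Three compounds of the series have numbers in a functional assay on the whole organism (strain Wister albino) for inhibition, with Rattus norvegicus as the target, read by paw edema, with stated times of 30 min and 3 h, at a dose of 10 mg/kg by the oral route; a lower number here means less inhibition, a higher number more inhibition at the dose given (going by the name of the read-out). Compound 1 `COc1ccc(N2CCN(Cn3nc(C(C)c4ccc(CC(C)C)cc4)oc3=S)CC2)cc1` gives 42.6%, compound 2 `CCOc1ccccc1N1CCN(Cn2nc(C(C)c3ccc(CC(C)C)cc3)oc2=S)CC1` gives 44.6%, and compound 3 `COc1ccc(N2CCN(Cn3nc(Cc4ccc(SC)cc4)oc3=S)CC2)cc1` gives 33.7%, the lowest of the three; its nearest neighbour is compound 1, within the scatter, and the gap to compound 2 lies beyond it. Among the measured compounds shown here, the one measured step, a number 2 percentage points higher from compound 1 to compound 2 (within the scatter), changes the aryl on the piperazine nitrogen and stays within the scatter. Compound 4 `CSc1ccc(Cc2nn(CN3CCN(c4ccc(F)cc4)CC3)c(=S)o2)cc1` differs from compound 3 by fluoro in place of methoxy on an aromatic carbon. For the measured compounds named here, no measured step exchanges these two groups; the only precedent at this position moved the read-out little, so no step beyond the scatter is expected. The expected step is a number 0.3 percentage points higher from compound 3 to compound 4 (within the scatter). Compound 4 is thus estimated at 34%, in the range 24% to 45% in this assay.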

Compound 4, a percentage reported as inhibition, in the whole organism at one dose (the size of the read-out at that dose, not a potency): 68.7%
Compound 4: middle estimate off by 34.7 percentage points, on the low side, and the stated range ends below it.
By their numbers in this assay, from the lowest: compounds 3, 1 and 2 (each within the scatter of the next, the first and the last beyond it); then compound 4.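

In this assay, the change from 4-methoxyphenyl to 4-fluorophenyl gives a number 35 percentage points higher from compound 3 to compound 4 (beyond the scatter), so this position is far from indifferent, although the earlier aryl change gave only a number 2 percentage points higher from compound 1 to compound 2 (within the scatter). That earlier step involved a different group and a different place on the ring, so it said little about fluoro. Nothing available explains the size of this step.

Still open, from the compounds shown here alone, is whether chloro or trifluoromethyl at this carbon would match fluoro. Also open, going by these compounds, is whether 4-fluorophenyl brings a similar step on the core of compound 1.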